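This account rests on a few compounds, and the source may have more. Where it says the series, first, only, none or still open, it means among the compounds named here.

Three compounds share one core and differ only in the group on the carbonyl carbon attached to the aromatic nitrogen. Compound 1 `Cc1nn(C(=O)C2CC2)c(N)c1-c1ccc(Cl)c(Cl)c1` gives 24300 nM in an assay on Sf9 cells for inhibition of mitogen-activated protein kinase kinase kinase 14 (Homo sapiens), read by ADP-Glo, with a stated time of 60 min; on this read-out lower numbers stand for stronger inhibition and higher numbers for weaker inhibition. Compound 2 `Cc1nn(C(=O)C2CCC2)c(N)c1-c1ccc(Cl)c(Cl)c1` gives 2900 nM in this assay, and compound 3 `Cc1nn(C(=O)c2ccncc2)c(N)c1-c1ccc(Cl)c(Cl)c1` gives 58200 nM. Compound 3 thus stands at the highest number of the three, the nearest being compound 1 and the furthest compound 2. The step of an 8.4-fold lower number from compound 1 to compound 2 (0.92 log units; beyond the scatter) was modest, the step of a 2.4-fold higher number from compound 1 to compound 3 (0.38 log units; beyond the scatter) was modest in the other direction, and the step of a 20-fold higher number from compound 2 to compound 3 (1.30 log units; beyond the scatter) was large.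

Compound 4 `Cc1nn(C(=O)OC(C)(C)C)c(N)c1-c1ccc(Cl)c(Cl)c1` differs from compound 3 by tert-butoxy in place of pyridin-4-yl on a carbonyl carbon. All three measured steps bear on this position, and two of them show a lower number when the pyridin-4-yl group is replaced by a carbon-based group without a ring heteroatom. A step of the size a 9.7-fold lower number from compound 3 to compound 4 (0.99 log units; beyond the scatter) is therefore expected, toward a lower number. Compound 4 is estimated at 6000 nM in this assay, within a range from 1500 nM to 25000 nM.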

Compound 4, half-maximal inhibitory concentration: > 100000 nM
Compound 4 was reported as a limit (the forecaster's own chance of this, stated with the estimate: 5%); at least 16-fold (1.22 log units) between middle value and limit.
By their numbers in this assay, from the lowest: compound 2; then compound 1; then compound 3. At a limit, above all of these: compound 4.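

Compound 4 is reported in this assay as a limit, not as a number: the limit of > 100000 nM in this assay, at which 1 of the 4 values shown sits. Tert-butoxy, the only group of the four with no ring, gives an at least 34-fold higher number from compound 2 to compound 4 (1.53 log units; beyond the scatter) and an at least 4.1-fold higher number from compound 1 to compound 4 (0.61 log units; beyond the scatter), so at this position the earlier gain from a cyclopropyl or cyclobutyl ring does not carry over to this open group. Against pyridin-4-yl the change gives an at least 1.7-fold higher number from compound 3 to compound 4 (0.23 log units; that floor lies within the scatter), and with that floor inside the scatter, the order of these two compounds remains unsettled.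

Since tert-butoxy differs from the rings both in having no ring and in bringing in oxygen, the compounds shown do not separate these two changes. From the compounds shown here alone, whether a cyclopentyl ring would continue the trend from cyclopropyl to cyclobutyl, or an isobutyl chain would behave like the rings or like tert-butoxy, also remains open.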